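The source may hold more compounds than are shown below. What is called first, only, known or untested is meant among the compounds shown, and "the series" means these compounds.

Compound 1 `Cc1ccc(-c2cn(/N=C/c3cc4ccccc4nc3Cl)c(N)n2)cc1` and compound 2 `COc1ccc(-c2cn(/N=C/c3cc4ccccc4nc3Cl)c(N)n2)cc1` share one core, while compound 3 `Cc1ccc(-c2cn(/N=C/c3cc4cc(C)ccc4nc3Cl)c(N)n2)cc1` and the not yet measured compound 4 `COc1ccc(-c2cn(/N=C/c3cc4cc(C)ccc4nc3Cl)c(N)n2)cc1` share another. The two cores differ by methyl in place of hydrogen on an aromatic carbon. In a functional assay on DLD-1 cells (Homo sapiens) for cytotoxicity, read by MTT assay, with a stated time of 48 h (a lower number here means a stronger inhibitor, a higher number a weaker inhibitor), compound 1 gives > 50000 nM, which is a limit of the assay rather than a number. Compound 2 likewise gives > 50000 nM, again a limit. Compound 3 gives 25200 nM. The change methoxy in place of methyl on an aromatic carbon therefore produced a step that the two limits leave unreadable from compound 1 to compound 2, because the limit of > 50000 nM in this assay, at which 2 of the 3 values shown sit, hides its size. Adding the methyl to the core gave an at least 1.9-fold lower number from compound 1 to compound 3 (0.29 log units; that floor lies within the scatter). Compound 4 repeats the change methoxy in place of methyl on an aromatic carbon on the core of compound 3, in the same place as before, so it is the same change made a second time. Since the first instance left no readable step, the expectation for compound 4 rests on compound 3 and its 25200 nM. The step is expected to be a 1.4-fold higher number from compound 3 to compound 4 (0.14 log units; within the scatter). Compound 4 is thus estimated at 35000 nM, within 15000 nM to 90000 nM, with a real chance that the assay again reports only a limit.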

Compound 4, half-maximal inhibitory concentration: 25700 nM
Compound 4: middle estimate off by 1.4-fold (0.13 log units), on the high side; low and high end bracket the measured number.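

Adding the methyl to the core gave an at least 1.9-fold lower number from compound 2 to compound 4 (0.28 log units; that floor lies within the scatter) in this assay, and this floor can be set beside the one from the first pair: the same change on two cores in this assay, an at least 1.9-fold lower number (0.29 log units; that floor lies within the scatter) from compound 1 to compound 3 and an at least 1.9-fold lower number (0.28 log units; that floor lies within the scatter) from compound 2 to compound 4; the limit leaves it open whether they differ. Replacing 4-methylphenyl with 4-methoxyphenyl on the methylated core gave a 1.0-fold higher number from compound 3 to compound 4 (0.01 log units; within the scatter), so on this core the swap shows no change beyond the scatter. Whether the same swap reads alike on the core without the added methyl, and how large the methyl step truly is on either pair, cannot be read, because the measured numbers stop at a limit for two compounds: the limit of > 50000 nM in this assay, at which 2 of the 4 values shown sit.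

As far as these compounds go, only methyl and methoxy appear on the outer aromatic ring here, so it stays open how an amine, a carboxylic acid or a longer chain in the same place would read. From the compounds shown here alone, whether any of these steps would hold in another cell line also remains open.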